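This account rests on a few compounds, and the source may have more. Where it says the series, first, only, none or still open, it means among the compounds named here.

Working notes on the series.

Compound 3 `O=[N+]([O-])c1ccc(Nc2nc(SCc3ccc(C(F)(F)F)cc3)nc3ccccc23)cc1` gives 8670 nM in a functional assay on MDA-MB-231 cells (Homo sapiens) for cytotoxicity, read by MTT assay, with a stated time of 72 h (a higher number here means a weaker inhibitor, a lower number a stronger inhibitor), and stands lowest of the two numbers in hand. Its nearest neighbour is compound 1 `CCCCCCCCNc1nc(SCc2ccc(C(F)(F)F)cc2)nc2ccccc12`, which in this assay gives 22300 nM. Compound 2 `FC(F)(F)c1ccc(CSc2nc(Nc3ccccc3Cl)c3ccccc3n2)cc1` gives > 50000 nM in this assay, and that is a limit. The swaps on the ring nitrogen so far read a 2.6-fold lower number from compound 1 to compound 3 (0.41 log units; beyond the scatter), an at least 2.2-fold higher number from compound 1 to compound 2 (0.35 log units; beyond the scatter) and an at least 5.7-fold lower number from compound 2 to compound 3 (0.76 log units; beyond the scatter); the last rests on (the limit of > 50000 nM in this assay, at which 1 of the 3 values shown sits), so its true size is open.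

Compound 4 `COc1ccc(Nc2nc(SCc3ccc(C(F)(F)F)cc3)nc3ccccc23)cc1OC` is the next swap at the same nitrogen: 3,4-dimethoxyphenyl in place of 4-nitrophenyl on a nitrogen on an aromatic ring. Within the data shown here, the steps that bear on it are the two aryl swaps into compound 3, both modest and both running toward the lower number held by compound 3. Moving off 4-nitrophenyl to 3,4-dimethoxyphenyl is thus read as a modest move back toward the numbers of compound 1 and compound 2, and the expected step is a 2.3-fold higher number from compound 3 to compound 4 (0.36 log units; beyond the scatter). Compound 4 is therefore expected at 20000 nM, with a range of 7000 nM to 60000 nM.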

Compound 4, half-maximal inhibitory concentration: 18900 nM
Beside the measured number, compound 4's estimate is 1.1-fold (0.02 log units) above it; measured number inside the range.
By their numbers in this assay, from the lowest: compound 3; then compounds 4 and 1 (each within the scatter of the next). At a limit, above all of these: compound 2.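

Compound 3 now keeps the lower number against a second substituted phenyl group on this nitrogen (a 2.2-fold higher number from compound 3 to compound 4 (0.34 log units; beyond the scatter)), so a phenyl group there does not by itself bring the number down. 3,4-Dimethoxyphenyl and octyl cannot be told apart here (a 1.2-fold lower number from compound 1 to compound 4 (0.07 log units; within the scatter)), which shows that an aryl group and a long alkyl chain can read alike in this assay. As far as these compounds go, the aryl groups also separate from one another, with 3,4-dimethoxyphenyl clear of 2-chlorophenyl (an at least 2.6-fold lower number from compound 2 to compound 4 (0.42 log units; beyond the scatter)), though compound 2 is a limit and the size of that step stays open: (the limit of > 50000 nM in this assay, at which 1 of the 4 values shown sits).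

From the compounds shown here alone, whether the lower number of compound 3 belongs to the nitro group itself remains open, and a 4-cyanophenyl or 4-aminophenyl group on this nitrogen would bear on that. Going by these compounds, how a shorter chain such as hexyl would read against octyl is also open.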